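Swapping chloro for nitro on the anilide ring

The source may hold more compounds than are shown below. What is called first, only, known or untested is meant among the compounds shown, and "the series" means these compounds.

Measured compounds:
- compound 1 `COc1cc2c(cc1OC)C(CC(=O)Nc1cccc(Cl)c1)CC2`: 25.8%
- compound 2 `COc1cc2c(cc1OC)C(CC(=O)Nc1ccc(Cl)cc1)CC2`: 8.08%

Of the compounds shown here, two sharing one core have been tested in a functional assay on the whole organism (strain Wistar) for inhibition, with Rattus norvegicus as the target, read by paw edema, at a dose of 100 mg/kg by the oral route; on this read-out lower numbers stand for less inhibition and higher numbers for more inhibition at the one dose given (going by the name of the read-out). Compound 1 `COc1cc2c(cc1OC)C(CC(=O)Nc1cccc(Cl)c1)CC2` gives 25.8%, and compound 2 `COc1cc2c(cc1OC)C(CC(=O)Nc1ccc(Cl)cc1)CC2` gives 8.08%. Within the data shown here, compound 2 thus has the lower of the two numbers; the only measured step, a number 17.7 percentage points lower from compound 1 to compound 2 (beyond the scatter), came with 4-chlorophenyl in place of 3-chlorophenyl on an amide-type nitrogen, a change of where the chloro sits rather than of which group sits there.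

Compound 3 `COc1cc2c(cc1OC)C(CC(=O)Nc1ccc([N+](=O)[O-])cc1)CC2` has not been measured. It differs from compound 2 by nitro in place of chloro on an aromatic carbon, on an aromatic carbon of a six-membered aromatic ring of carbon only, para to a large group. Among the measured compounds shown here, no measured step exchanges one group for another at this place, so the data give no direction for this change. Compound 3 is therefore expected to land near compound 2, with the step of a number 6.9 percentage points higher from compound 2 to compound 3 (within the scatter) estimated at no clear size beyond the scatter. Compound 3 is estimated at 15%, within a range from 0% to 35%.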

Compound 3, a percentage reported as inhibition, in the whole organism at one dose (the size of the read-out at that dose, not a potency): 17.7%
Estimate against measurement, compound 3: 2.7 percentage points below; the range from low to high includes it.
By their numbers in this assay, from the lowest: compounds 2, 3 and 1 (each within the scatter of the next, the first and the last beyond it).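

In this assay, among these compounds, this is the first exchange of one group for another at this place on the anilide ring, and it gives a number 9.6 percentage points higher from compound 2 to compound 3 (within the scatter). The earlier step, a number 17.7 percentage points lower from compound 1 to compound 2 (beyond the scatter), came from moving the chloro, whereas here a single chlorine atom gives way to the three heavy atoms of nitro, with two hydrogen-bond acceptors entering, and the read-out stays within the usual scatter. So at this place, on an aromatic carbon para to a large group, these two groups cannot be told apart by this read-out, and no measurement of any property of the compounds bears on why.

This single exchange sets no trend, and an amine, a carboxylic acid or a methoxy group on this same carbon could still give a step beyond the scatter. It also remains open whether moving the nitro around the ring would matter in the way that moving the chloro did, since the compounds shown carry nitro at this one place only.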